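A few compounds are considered here, and "the series" means these few. Any claim that something is new, unique, unknown or untested is made for them only; others in the source may bear on it.

In a functional assay on HeLa S3 cells (Homo sapiens) for antiproliferative activity, read by XTT assay, with a stated time of 72 h (a lower number here means a stronger inhibitor, a higher number a weaker inhibitor), compound 1, `Nc1nc2c(c(-c3ccccc3)cn2[C@@H]2O[C@H](CO)[C@@H](O)[C@H]2O)c(=O)[nH]1`, gives only a limit, > 20000 nM. Among the compounds with values here, compound 2, `Nc1nc2c(c(-c3ccoc3)cn2[C@@H]2O[C@H](CO)[C@@H](O)[C@H]2O)c(=O)[nH]1`, gives 10700 nM in this assay, the only number in the set. The other entry, that of compound 1, is a limit (the limit of > 20000 nM in this assay, at which 1 of the 2 values shown sits). Within the data shown here, the sole measured step, an at least 1.8-fold lower number from compound 1 to compound 2 (0.27 log units; that floor lies within the scatter), stays within the scatter. Compound 3, `Nc1nc2c(c(-c3cc4ccccc4o3)cn2[C@@H]2O[C@H](CO)[C@@H](O)[C@H]2O)c(=O)[nH]1`, differs from compound 2 by 1-benzofuran-2-yl in place of furan-3-yl on an aromatic carbon. Among the measured compounds shown here, no measured step exchanges these two groups, and the one measured step gives no direction beyond the scatter, so compound 3 is expected to stay near compound 2, with an estimated step of a 1.1-fold lower number from compound 2 to compound 3 (0.03 log units; within the scatter). Compound 3 is therefore estimated at 10000 nM, between 3000 nM and 30000 nM.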

Compound 3, half-maximal inhibitory concentration: > 20000 nM
Compound 3: no number, only a limit; the forecaster's own chance of this, stated with the estimate: 30%; middle value at least 2.0-fold (0.30 log units) from the limit.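

At this position, the larger 1-benzofuran-2-yl does not keep the measurable value seen with furan-3-yl: in this assay compound 3 gives only a limit, > 20000 nM. The change is an at least 1.8-fold higher number from compound 2 to compound 3 (0.27 log units; that floor lies within the scatter), so it establishes no loss beyond the scatter. The step between compound 1 and compound 3 cannot be read, and the limit is shared by both: the limit of > 20000 nM in this assay, at which 2 of the 3 values shown sit.

Left open is whether furan-2-yl, or a furan-3-yl carrying an amine, would give a number clearly beyond the scatter from compound 2.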